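This account rests on a few compounds, and the source may have more. Where it says the series, first, only, none or still open, it means among the compounds named here.

Measured compounds:
compound 1 `CCCCn1cc(COc2cc(O)c3c(c2)O[C@H](c2ccc(OC)c(O)c2)C/C3=N\O)nn1` — 8900 nM
compound 2 `COc1ccc([C@@H]2CC(=O)c3c(O)cc(OCc4cn(Cc5cccc(C(F)(F)F)c5)nn4)cc3O2)cc1O` — 19900 nM

In a functional assay on RAW264.7 cells (Mus musculus) for inhibition, read by Griess assay, with stated times of 2 h and 24 h (a higher number here means a weaker inhibitor, a lower number a stronger inhibitor), compound 2 gives 19900 nM, the higher of the two numbers; compound 1 gives 8900 nM, a gap beyond the scatter. Compound 3 `COc1ccc([C@@H]2CC(=O)c3c(O)cc(OCc4cn(Cc5ccc(Cl)cc5)nn4)cc3O2)cc1O` has not been measured. It differs from compound 2 in one place: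

4-chlorophenyl in place of 3-(trifluoromethyl)phenyl on a saturated chain carbon bound to an aromatic nitrogen

Among the compounds with values here, no measured pair shows this change, so its effect is unknown. The step from compound 2 to compound 3 is expected to be small, a 1.3-fold lower number from compound 2 to compound 3 (0.12 log units; within the scatter), not beyond the scatter in either direction. Compound 3 is therefore estimated at 15000 nM, within 6000 nM to 40000 nM.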

Compound 3, half-maximal inhibitory concentration: 17800 nM
For compound 3 the middle estimate is 1.2-fold (0.07 log units) below the measured one, within the range that was stated.
By their numbers in this assay, from the lowest: compounds 1, 3 and 2 (each within the scatter of the next, the first and the last beyond it).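

In this assay the step from 3-(trifluoromethyl)benzyl to 4-chlorobenzyl gives a 1.1-fold lower number from compound 2 to compound 3 (0.05 log units; within the scatter) and so puts the two groups level at this place, on a saturated chain carbon bound to an aromatic nitrogen. Within the data shown here, the earlier compounds offered no pair differing here alone, so this is the first direct reading of this position. No available evidence bears on the reason for this result. On these data alone, whether an amine, a carboxylic acid or a longer chain at this place would give a different number stays open. Compound 1 differs from compound 2 and compound 3 in more than one place, so its gap to compound 2 cannot be assigned to any single group.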